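Swapping a Side Chain in Two Weakly Active Amides

The compounds below may be only part of what the source reports. "The series", "measured", "known", "first", "only" and "open" are said of these compounds alone.

Measured compounds:
compound 1 `O=C(O)[C@@H]1CCCN1C(=O)CN(c1nc(Cl)nc2[nH]cnc12)C1CC1`: 7.29%
compound 2 `O=C(CN(c1nc(Cl)nc2[nH]cnc12)C1CC1)N[C@@H](CC(=O)OCc1ccccc1)C(=O)OCc1ccccc1`: 6.68%

In a functional assay on the whole organism (Tail, strain ICR) with Mus musculus as the target, in the tail flick test, with a stated time of 150 min, at a dose of 25 umol/kg by the oral route (a higher number here means a stronger effect of the compound at the dose given, a lower number a weaker effect), compound 1 gives 7.29%. In the same test compound 2 gives 6.68%. Compound 2 thus sits alongside compound 1, the gap between the two numbers falling within the usual scatter, so neither can be called stronger than the other; both show only a faint effect at this dose.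

Compound 3 `CC(C)[C@H](NC(=O)CN(c1nc(Cl)nc2[nH]cnc12)C1CC1)C(=O)OCc1ccccc1` has not yet been tested in this assay. It differs from compound 2 in one place: isopropyl in place of (benzyloxycarbonyl)methyl on a saturated chain carbon bound to an amide-type nitrogen and a carbonyl carbon. Going by the values given here, nothing measured so far shows how this kind of change moves the read-out, and the two known compounds give no sign of any large effect from changes on this side of the molecule. The step from compound 2 to compound 3 is therefore expected to be a number 1.3 percentage points higher from compound 2 to compound 3 (within the scatter), that is, no change beyond the scatter. Compound 3 is estimated to give 8%, with a likely range from 0% to 20%.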

Compound 3, a percentage reported as activity, at one dose (the size of the read-out at that dose, not a potency): 17.9%
For compound 3 the middle estimate is 9.9 percentage points below the measured one, within the range that was stated.
By their numbers in this assay, from the lowest: compounds 2 and 1 (each within the scatter of the next); then compound 3.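

Going by these compounds alone, on the saturated chain carbon bound to an amide-type nitrogen and a carbonyl carbon, the side chain does matter: in this assay, isopropyl in place of (benzyloxycarbonyl)methyl gives a number 11.2 percentage points higher from compound 2 to compound 3 (beyond the scatter) and is the first change here to move the read-out beyond the scatter. The group that leaves has 11 heavy atoms and an aromatic ring, the group that enters has 3 heavy atoms and no ring, and the other benzyl ester of the molecule stays in place. Nothing at hand explains the rise.

This single step cannot show whether the gain follows from having isopropyl or from losing the aromatic ring. A methyl, a longer chain such as butyl, or a carboxylic acid on this carbon would help to separate the two.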